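This account rests on a few compounds, and the source may have more. Where it says the series, first, only, none or still open, it means among the compounds named here.

Measured so far:
compound 1 `Cc1c(COc2cc(OCCC(C)(C)O)ccn2)[nH]c2ccccc2c1=O` — 112 mL/min/kg
compound 2 `Cc1c(COCCCCOCC2(C)COC2)[nH]c2ccccc2c1=O` — 295 mL/min/kg
compound 3 `Cc1c(COc2cccc(OCC3CCOCC3)c2)[nH]c2ccc(Cl)cc2c1=O` — > 1000 mL/min/kg

In an in vitro ADME assay on microsomes from liver (Mus musculus) for metabolic stability, tested at 0.2 uM (a higher number here means faster removal of the compound, a lower number slower removal), compound 1 gives 112 mL/min/kg and compound 2 gives 295 mL/min/kg. Compound 3 stands at the top of these numbers: its value of > 1000 mL/min/kg in this assay is a limit of the assay rather than a number, and (the limit of > 1000 mL/min/kg in this assay, at which 1 of the 3 values shown sits). Compound 4 `Cc1c(COc2cccc(OCC3CCOCC3)c2)[nH]c2ccccc2c1=O` differs from compound 3 by hydrogen in place of chloro on an aromatic carbon. Within the data shown here, no measured pair shows this change, so its size in this assay is only an expectation: a modest fall, perhaps no more than the scatter, with the estimated step being an at least 1.4-fold lower number from compound 3 to compound 4 (0.15 log units; that floor lies within the scatter). Compound 4 is expected to give about 700 mL/min/kg in this assay, within a range of 300 mL/min/kg to 1500 mL/min/kg.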

Compound 4, clearance: 420 mL/min/kg
The estimate for compound 4 lay 1.7-fold (0.22 log units) above the measured number; the range from low to high includes it.
By their numbers in this assay, from the lowest: compound 1; then compounds 2 and 4 (each within the scatter of the next). At a limit, above all of these: compound 3.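

Hydrogen in place of chloro on this aromatic carbon gives an at least 2.3-fold lower number from compound 3 to compound 4 (0.37 log units; beyond the scatter) in this assay, the first step measured at this position. On these data alone, with hydrogen there, compound 4 gives a number, whereas compound 3 gives only a limit, so the step is a floor and its full size remains unknown: the limit of > 1000 mL/min/kg in this assay, at which 1 of the 4 values shown sits. As far as these compounds go, what fluoro, methyl or methoxy would do on the same aromatic carbon stays open. So does whether the step holds when the rest of the molecule carries an amine.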